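Bromo for methyl: expected clearance of compound 3

This account rests on a few compounds, and the source may have more. Where it says the series, first, only, none or still open, it means among the compounds named here.

Among the compounds with values here, compound 2 `Cc1ccc([C@H](C)NC(=O)c2ccc(Sc3ccc(N)cc3)c(Nc3ncnc4nc(C(C)C)ccc34)c2)cc1` stands highest of the two numbers so far in an ADME assay on the whole organism (strain Sprague-Dawley) for pharmacokinetics, with Rattus norvegicus as the target, at a dose of 5 mg/kg by the intravenous route (on this read-out lower numbers stand for slow clearance and higher numbers for fast clearance), where compound 2 gives 18.3 mL/min/kg. Compound 1 `CC(C)c1ccc2c(Nc3cc(C(=O)N[C@@H](C)c4ccccc4)ccc3Sc3ccc(N)cc3)ncnc2n1` gives 5.5 mL/min/kg in this assay. Within the data shown here, the single measured step that joins them, a 3.3-fold higher number from compound 1 to compound 2 (0.52 log units; beyond the scatter), is a methyl in place of hydrogen on an aromatic carbon. Compound 3 `CC(C)c1ccc2c(Nc3cc(C(=O)N[C@@H](C)c4ccc(Br)cc4)ccc3Sc3ccc(N)cc3)ncnc2n1` differs from compound 2 by bromo in place of methyl on an aromatic carbon, para to a large group. Among the measured compounds shown here, no measured step shows bromo entering in place of methyl, so the one step that bears on this exchange only indirectly is a 3.3-fold higher number from compound 1 to compound 2 (0.52 log units; beyond the scatter), which says what a group at that carbon did once. The step expected in this assay, a 1.3-fold lower number from compound 2 to compound 3 (0.12 log units; within the scatter), is therefore small and uncertain in direction. Compound 3 is estimated at 14 mL/min/kg, within a range from 6 mL/min/kg to 32 mL/min/kg.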

Compound 3, clearance: 5.67 mL/min/kg
Beside the measured number, compound 3's estimate is 2.5-fold (0.39 log units) above it; the whole stated range lies above it.
By their numbers in this assay, from the lowest: compounds 1 and 3 (each within the scatter of the next); then compound 2.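

In this assay the exchange at this carbon, para to a large group, gives a 3.2-fold lower number from compound 2 to compound 3 (0.51 log units; beyond the scatter) (a step beyond the scatter), so the outcome at this position depends on which group stands there and not only on whether the hydrogen has been replaced. Bromo in place of hydrogen gives a 1.0-fold higher number from compound 1 to compound 3 (0.01 log units; within the scatter) and stays within the scatter, so among the three groups seen at this carbon, only methyl stands apart from the other two. Nothing in hand gives a reason for this difference between methyl and bromo.

On these data alone, whether chloro, methoxy or a longer chain such as ethyl at this carbon would fall with hydrogen and bromo or with methyl stays open. So does whether the same gap would hold after a change elsewhere on the shared core.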